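Removing the Ring Methyl From Compound 2

The compounds below may be only part of what the source reports. "The series", "measured", "known", "first", "only" and "open" are said of these compounds alone.

Of the compounds shown here, three have been measured in a functional assay on PC-3 cells (Homo sapiens) for cytotoxicity, read by MTT assay, with a stated time of 72 h; on this read-out higher numbers stand for weaker inhibition and lower numbers for stronger inhibition. Compound 1 `COc1cc(Nc2nc(C(=N)Nc3ccc(N4CCN(C)CC4)cc3)cc3c(-c4ccccc4)n[nH]c23)cc(OC)c1OC` gives 4300 nM, compound 2 `Cn1nc(-c2ccccc2)c2cc(C(=N)Nc3ccccc3)ncc21` gives 17300 nM, and compound 3 `Cn1nc(-c2ccccc2)c2cc(C(=N)Nc3cccc(C(F)(F)F)c3)ncc21` gives 20900 nM. Compound 2 thus stands second highest of the three numbers; its gap to compound 3 lies within the scatter, while its gap to compound 1 lies beyond it. For the measured compounds named here, the only step measured between close relatives, a 1.2-fold higher number from compound 2 to compound 3 (0.08 log units; within the scatter), is within the scatter.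

Compound 4 `N=C(Nc1ccccc1)c1cc2c(-c3ccccc3)n[nH]c2cn1` is the unmeasured partner of compound 2. The change is hydrogen in place of methyl on an aromatic nitrogen. Going by the values given here, no measured step bears directly on this change: the step from compound 2 to compound 3 alters a different part of the molecule, and compound 1, which carries hydrogen on the aromatic nitrogen, differs from compound 2 in several other places, so its value offers no clean comparison. With nothing in the measured data pointing to a shift, the step in this assay is expected to fall within the scatter, with no preferred direction.

Compound 4 is therefore estimated at 15000 nM, within a range from 5000 nM to 45000 nM. That estimate corresponds to an expected step of a 1.2-fold lower number from compound 2 to compound 4 (0.06 log units; within the scatter), which is expected to lie within the scatter.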

Compound 4, half-maximal inhibitory concentration: 23000 nM
For compound 4 the middle estimate is 1.5-fold (0.19 log units) below the measured one; low and high end bracket the measured number.
By their numbers in this assay, from the lowest: compound 1; then compounds 2, 3 and 4 (each within the scatter of the next).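

In this assay, the exchange of methyl for hydrogen on the aromatic nitrogen of the five-membered ring gives a 1.3-fold higher number from compound 2 to compound 4 (0.12 log units; within the scatter). For the compounds shown here, this is the first step measured directly at this position, as the earlier step between close relatives concerned a different part of the molecule, and it shows that, within the scatter of the assay, methyl and hydrogen on this nitrogen cannot be told apart for this pair. No supporting evidence is available on this result, so the data give no account of why the exchange leaves the two numbers within the scatter.

This single pair says nothing about whether a larger group on the same nitrogen, such as an ethyl group or a longer chain ending in an amine, would take the number beyond the scatter in this assay. It also leaves open whether the exchange of methyl for hydrogen would stay within the scatter on the core of compound 1, which carries hydrogen on this nitrogen alongside its other groups.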